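Replacing a Pyrrolidine Amide with a Methoxypiperidine Amide

A few compounds are considered here, and "the series" means these few. Any claim that something is new, unique, unknown or untested is made for them only; others in the source may bear on it.

Measured compounds:
compound 1 `O=C(C1CCC1)N1CC(c2nc(-c3cccc(Cl)c3)no2)C1` — > 10000 nM
compound 2 `CC1CCN(C(=O)N2CC(c3nc(-c4cccc(Cl)c4)no3)C2)C1` — > 10000 nM
compound 3 `Cc1ccc(C(=O)N2CC(c3nc(-c4cccc(F)c4)no3)C2)cc1` — 6800 nM

In an assay on HEK293 cells for positive allosteric modulation of metabotropic glutamate receptor 5 (Homo sapiens), read by FLIPR (on this read-out higher numbers stand for an effect only at larger amounts of compound and lower numbers for an effect already at smaller amounts), compound 2 gives only a limit, > 10000 nM. Compound 1 gives only a limit as well, > 10000 nM. Compound 3 gives a number, 6800 nM. Two of the three values sit at the limit of > 10000 nM in this assay, at which 2 of the 3 values shown sit. Within the data shown here, the one single-point step between measured compounds, a step that the two limits leave unreadable from compound 1 to compound 2, cannot be read for size.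

Compound 4 `COC1CCN(C(=O)N2CC(c3nc(-c4cccc(Cl)c4)no3)C2)CC1` differs from compound 2 by 4-methoxypiperidin-1-yl in place of 3-methylpyrrolidin-1-yl on a carbonyl carbon. Among the measured compounds shown here, no measured step tells how this change acts, so the expectation is simply that compound 4 stays near where compound 2 stands, a step that the limit leaves unreadable from compound 2 to compound 4. Compound 4 is estimated at 12000 nM, within 4000 nM to 40000 nM.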

Compound 4, half-maximal effective concentration: > 10000 nM
Compound 4 ended at the assay's limit; the forecaster's own chance of this, stated with the estimate: 65%; the middle value does not contradict the limit.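

Among these compounds, no step among compound 1, compound 2 and compound 4 can be read, since all three stop at a limit of the assay, not a number: the limit of > 10000 nM in this assay, at which 3 of the 4 values shown sit.

Going by these compounds, how these amide groups differ in effect on the shared core stays open.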